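A few compounds are considered here, and "the series" means these few. Any claim that something is new, unique, unknown or untested is made for them only; others in the source may bear on it.

Working notes on the series, whose members carry the same shared core. In a physicochemical assay for solubility, read by LC-MS, in phosphate buffer, with a stated time of 24 h, at pH 7.4 (a lower number here means a less soluble compound, a higher number a more soluble compound), compound 1 (`Fc1ccc2c(c1CNc1ncc(Oc3ccccc3)c3nncn13)CCO2`) reads 8000 nM. Compound 3 (`CN(C)Cc1ccc2c(c1)CN(c1cnc(NCc3c(F)ccc4c3CCO4)n3cnnc13)C2=O`) reads 12000 nM, within the usual scatter of compound 1, so these two cannot be ordered. Compound 2 (`CN(C)Cc1ccc(C(=O)Nc2cnc(NCc3c(F)ccc4c3CCO4)n3cnnc23)cc1`) reads 520000 nM, a gap to compound 1 well beyond the scatter. Compound 1 therefore stands at the low end of the three numbers, together with compound 3.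

Next in line is compound 4 (`CN(c1ccn(C)n1)c1cnc(NCc2c(F)ccc3c2CCO3)n2cnnc12`), not yet measured. It carries methyl(1-methyl-1H-pyrazol-3-yl)amino in place of phenoxy on an aromatic carbon. For the measured compounds named here, no measured pair differs in one place only, so this exchange has no direct precedent. Going by the values given here, compound 3 at 12000 nM and compound 2 at 520000 nM carry other groups on that same carbon, and they show only that numbers can stay close to compound 1 or lie far higher. A moderate upward move in this assay is the working expectation, closer to compound 3 than to compound 2. The expected step is a 3.8-fold higher number from compound 1 to compound 4 (0.57 log units; beyond the scatter), only modestly beyond the scatter. The estimate for compound 4 is 30000 nM, with an expected range of 10000 nM to 100000 nM.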

Compound 4, solubility: 130000 nM
Compound 4: middle estimate off by 4.3-fold (0.64 log units), on the low side, and the stated range ends below it.
By their numbers in this assay, from the lowest: compounds 1 and 3 (each within the scatter of the next); then compound 4; then compound 2.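

For the compounds shown here, compound 1 and compound 4 form the first pair that differs in one place, which gives the aromatic carbon para to a large group a direct reading in this assay. Methyl(1-methyl-1H-pyrazol-3-yl)amino in place of phenoxy gives a 16-fold higher number from compound 1 to compound 4 (1.21 log units; beyond the scatter), so the exchange of this one group, with the shared core unchanged, is enough for a large step, and neither group carries a net charge or a hydrogen-bond donor. No measurement at hand accounts for the size of this step.

Going by these compounds, the exchange changes several things at once: the oxygen link gives way to a methylated nitrogen link, the six-membered aromatic ring of carbon only gives way to a five-membered aromatic ring with 2 hetero atoms, and the count goes from 1 hydrogen-bond acceptor to 3 hydrogen-bond acceptors, so the share of each in the step remains open. Methyl(phenyl)amino and 1-methyl-1H-pyrazol-3-yloxy on this same carbon would separate the link from the ring.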